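Taking the Hydroxy Away Again: an Unmeasured Analogue

The source may hold more compounds than are shown below. What is called first, only, known or untested is meant among the compounds shown, and "the series" means these compounds.

Compound 2 `CCCN(CC1CC1)c1cc(C(C)(O)c2c(OC)cc(OC)cc2OC)nc(C)n1` carries the only numerical result of the series in an assay on isolated protein for binding affinity to corticotropin-releasing factor receptor 1 (Homo sapiens) (a higher number here means a weaker inhibitor, a lower number a stronger inhibitor), where compound 2 gives 1900 nM. Compound 1 `CCCN(CC1CC1)c1cc(C(C)(C)c2c(OC)cc(OC)cc2OC)nc(C)n1` reaches only the limit of the assay, so in this assay compound 1 gives > 10000 nM, a limit and not a number. Within the data shown here, the one measured step, an at least 5.2-fold lower number from compound 1 to compound 2 (0.72 log units; beyond the scatter), therefore rests on (the limit of > 10000 nM in this assay, at which 1 of the 2 values shown sits). Compound 3 `CCCN(CC1CC1)c1cc(C(C)c2c(OC)cc(OC)cc2OC)nc(C)n1` has not yet been measured; it differs from compound 2 by hydrogen in place of hydroxy on a saturated chain carbon bound to two aromatic carbons and a saturated chain carbon. Among the measured compounds shown here, the measured step bears on this change only partly: it put hydroxy in place of methyl, whereas the new change removes the hydroxy and leaves hydrogen, for which there is no direct precedent among the measured compounds. A moderate rise in the number, a 2.6-fold higher number from compound 2 to compound 3 (0.42 log units; beyond the scatter), is nevertheless expected, since the measured step of an at least 5.2-fold lower number from compound 1 to compound 2 (0.72 log units; beyond the scatter) ran in favour of hydroxy. Compound 3 is accordingly expected to give 5000 nM in this assay, with a range from 1500 nM to 20000 nM.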

Compound 3, inhibition constant: 480 nM
For compound 3 the middle estimate is 10-fold (1.02 log units) above the measured one; the measured number lies below the stated range.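

The result changes how the earlier step reads: hydroxy was better than methyl on this saturated chain carbon bound to two aromatic carbons and a saturated chain carbon, but it is not the best of the groups shown, since in this assay there is a 4.0-fold lower number from compound 2 to compound 3 (0.60 log units; beyond the scatter). The three compounds therefore fall into one order at this carbon, with the number falling from methyl to hydroxy to hydrogen, and the widest gap is an at least 20-fold lower number from compound 1 to compound 3 (1.31 log units; beyond the scatter). Compound 1 gives > 10000 nM, a limit and not a number, so the true size of that widest gap stays unknown and only its direction can be read: the limit of > 10000 nM in this assay, at which 1 of the 3 values shown sits.

What the compounds shown leave open is where other groups on this carbon would fall in the order, for example fluorine, an amine or a longer chain such as ethyl in place of the methyl that compound 3 keeps. They also leave open whether the same order would hold if the propyl or cyclopropylmethyl groups on the nitrogen of the shared core gave way to others, since all three compounds carry the same ones.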